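Methoxy in place of chloro on a shared core

The source may report more compounds than this note shows. Statements on the series, on what has been measured and on what is new or still open speak of the compounds shown alone.

Among the measured compounds shown here, in a functional assay on L1210 (1565) cells (Mus musculus) for cytotoxicity (on this read-out higher numbers stand for an effect only at larger amounts of compound and lower numbers for an effect already at smaller amounts), compound 1 (`Oc1ccc2nc(-c3ccccc3)cc(O)c2c1`) gives 0.83 ug/mL and compound 2 (`Oc1cc(-c2ccccc2)nc2ccc(Cl)cc12`) gives 0.5 ug/mL, so compound 2 stands level with its only neighbour once the usual scatter is allowed for. Compound 3 (`COc1ccc2nc(-c3ccccc3)cc(O)c2c1`) carries methoxy in place of chloro on an aromatic carbon. For the measured compounds named here, the one measured step of this kind, a change of group on that carbon, is a 1.7-fold lower number from compound 1 to compound 2 (0.22 log units; within the scatter), which is small. No step beyond the scatter is therefore expected in this assay, in either direction. The expected step is a 1.4-fold higher number from compound 2 to compound 3 (0.15 log units; within the scatter). For compound 3 the estimated value is 0.7 ug/mL, with an expected range from 0.25 ug/mL to 2 ug/mL.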

Compound 3, half-maximal effective concentration: 0.06 ug/mL
For compound 3 the middle estimate is 12-fold (1.07 log units) above the measured one; measured number outside the range, below it.
By their numbers in this assay, from the lowest: compound 3; then compounds 2 and 1 (each within the scatter of the next).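

In this assay methoxy in place of chloro gives an 8.3-fold lower number from compound 2 to compound 3 (0.92 log units; beyond the scatter) and methyl in place of hydrogen on the oxygen gives a 14-fold lower number from compound 1 to compound 3 (1.14 log units; beyond the scatter). The earlier pair suggested that the group on this aromatic carbon mattered little, yet hydroxy and chloro stay level within the scatter while methoxy stands clearly apart, so one added methyl on that oxygen is enough to separate compound 3 from compound 1. Nothing available explains this difference. Still open, as far as these compounds go, is whether the lower number is particular to methoxy or extends to a longer chain on that oxygen, such as ethoxy, or to an amine on the same carbon.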